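A few compounds are considered here, and "the series" means these few. Any claim that something is new, unique, unknown or untested is made for them only; others in the source may bear on it.

Measured so far in a functional assay on HeLa cells (Homo sapiens) for cytotoxicity, read by MTT assay, with a stated time of 48 h; a lower number here means a stronger inhibitor, a higher number a weaker inhibitor:

compound 1 `CCOC(=O)c1c(-c2cc3ccccc3oc2=O)nn(-c2cccc(C)c2)c1C(=O)OCC`: 245000 nM
compound 2 `CCOC(=O)c1c(-c2cc3ccccc3oc2=O)nn(-c2ccc(OC)cc2)c1C(=O)OCC`: 90000 nM
compound 3 `CCOC(=O)c1c(-c2cc3ccccc3oc2=O)nn(-c2cccc(F)c2)c1C(=O)OCC`: 68000 nM

Compound 3 has the lowest of the three numbers. The step of a 1.3-fold lower number from compound 2 to compound 3 (0.12 log units; within the scatter) lies within the usual scatter, so the two cannot be told apart; the step of a 3.6-fold lower number from compound 1 to compound 3 (0.56 log units; beyond the scatter) is beyond the scatter.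

Compound 4 `CCOC(=O)c1c(-c2cc3ccccc3oc2=O)nn(-c2ccc(Cl)cc2)c1C(=O)OCC` differs from compound 3 in one place: 4-chlorophenyl in place of 3-fluorophenyl on an aromatic nitrogen. Two earlier steps bear on this. Moving a group from one position on the phenyl to another, as in a 1.3-fold lower number from compound 2 to compound 3 (0.12 log units; within the scatter), stayed within the scatter. Swapping one small substituent for another on that phenyl gave a 2.7-fold lower number from compound 1 to compound 2 (0.43 log units; beyond the scatter) and a 3.6-fold lower number from compound 1 to compound 3 (0.56 log units; beyond the scatter), both modest. Replacing the fluorine of compound 3 with a chlorine at a different position on the same phenyl is therefore expected to move this assay little, likely within the scatter or by a modest amount in either direction. The expected step is a 1.1-fold lower number from compound 3 to compound 4 (0.05 log units; within the scatter). For compound 4 the estimated value in this assay is 60000 nM, with a range from 25000 nM to 150000 nM.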

Compound 4, half-maximal inhibitory concentration: 87000 nM
Estimate against measurement, compound 4: 1.5-fold (0.16 log units) below; the measured number falls inside the stated range.
By their numbers in this assay, from the lowest: compounds 3, 4 and 2 (each within the scatter of the next); then compound 1.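

In this assay the change from 3-fluorophenyl to 4-chlorophenyl on the aromatic nitrogen gives a 1.3-fold higher number from compound 3 to compound 4 (0.11 log units; within the scatter) and the change from methoxy to chloro gives a 1.0-fold lower number from compound 2 to compound 4 (0.01 log units; within the scatter) so the 3-fluorophenyl, 4-methoxyphenyl and 4-chlorophenyl compounds cannot be told apart here. The 3-methylphenyl group alone stands apart, with a 2.8-fold lower number from compound 1 to compound 4 (0.45 log units; beyond the scatter) as a third step of modest size, so all three other groups on this nitrogen now sit beyond the scatter from compound 1. Compound 3 and compound 4 differ in both the halogen and its place on the phenyl, so the contribution of each change cannot be separated, and the small net step could be a true absence of effect or two effects that offset each other.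

No measurement shown here explains why the 3-methylphenyl compound stands apart. Still open, on these data alone, is whether an amine or a carboxylic acid on the phenyl, or a longer chain in place of an ethoxycarbonyl group, would move the number in this assay further than any of these phenyl changes has.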